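This account rests on a few compounds, and the source may have more. Where it says the series, first, only, none or still open, it means among the compounds named here.

Of the compounds shown here, three have been measured in an in vitro assay on HEK293 cells for binding affinity to 5-hydroxytryptamine receptor 7 (Rattus norvegicus); a lower number here means a stronger inhibitor, a higher number a weaker inhibitor. Compound 1 `COc1ccc(S(=O)(=O)NCCCN2CCN(c3ccccc3OC)CC2)cc1` gives 100 nM in this assay. Compound 2 `CCN(CCCN1CCc2cc(OC)ccc2C1)S(=O)(=O)c1ccccc1` gives 54 nM in this assay. Compound 3 `COc1ccc2c(c1)CCN(CCCNS(=O)(=O)c1ccc(C)cc1)C2` gives 520 nM in this assay, the highest of the three numbers; its gaps to compound 1 and to compound 2 both lie beyond the usual scatter, so compound 3 is the weakest binder among those measured. Compound 4 `CCN(CCCN1CCc2cc(OC)ccc2C1)S(=O)(=O)c1ccc(C)cc1` has not yet been measured. It differs from compound 3 in one place: ethyl in place of hydrogen on a sulfonamide nitrogen. Within the data shown here, compound 2 carries that same ethyl on its sulfonamide nitrogen, but it also differs from compound 3 elsewhere, so no single-change step between them can be read; their two values simply show compound 2 with the lower number. No direct measurement of this change exists. The step from compound 3 to compound 4 in this assay is expected to be a decrease of about a 5.8-fold lower number from compound 3 to compound 4 (0.76 log units; beyond the scatter) because compound 2 gives 54 nM. Compound 4 is therefore estimated at 90 nM, with a likely range from 30 nM to 270 nM.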

Compound 4, inhibition constant in the 5-hydroxytryptamine receptor 7 assay: 11 nM
Compound 4: middle estimate off by 8.2-fold (0.91 log units), on the high side, and the stated range ends above it.
By their numbers in the 5-hydroxytryptamine receptor 7 assay, from the lowest: compound 4; then compounds 2 and 1 (each within the scatter of the next); then compound 3.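

Among these compounds, in the 5-hydroxytryptamine receptor 7 assay, ethyl in place of hydrogen on a sulfonamide nitrogen gives a 47-fold lower number from compound 3 to compound 4 (1.67 log units; beyond the scatter), the first direct reading of this change, and it shows that this nitrogen is a place where a small alkyl group can shift binding strongly. Among the compounds shown here, the other single change, methyl in place of hydrogen on an aromatic carbon, gives in the 5-hydroxytryptamine receptor 7 assay a 4.9-fold lower number from compound 2 to compound 4 (0.69 log units; beyond the scatter), a modest step that separates the contribution of this methyl from that of the ethyl, which the earlier compounds could not do. The ethyl change also comes with a shift in a physicochemical assay for acid dissociation, where compound 3 gives 7 and compound 4 gives 7.4, though that shift alone does not establish what drives the binding step: the measured acid dissociation constant of compound 3, 7, and of compound 4, 7.4, a number 0.40 log units higher (beyond the scatter)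

Going by these compounds, whether methyl or a longer chain such as propyl on this sulfonamide nitrogen would lower the number further remains open. So does whether ethyl at this place has a similar effect on the core of compound 1.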